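The source may hold more compounds than are shown below. What is called first, only, known or untested is meant among the compounds shown, and "the series" means these compounds.

Compound 3, `O=C(O)c1cccc(Cc2c(C3CCCCC3)nn3cc(Cl)ccc23)n1`, gives 1200 nM in a functional assay on cells for antagonist activity at prostaglandin E2 receptor EP1 subtype (Rattus norvegicus), read by fluorescence and calcium flux, with a stated time of 60 s (a higher number here means a weaker inhibitor, a lower number a stronger inhibitor), and so has the highest number among the three measured compounds. Its nearest neighbour is compound 1, `O=C(O)c1cccc(Cc2c(-c3cccc(Cl)c3)nn3cc(Cl)ccc23)n1`, which gives 480 nM; the step of a 2.5-fold higher number from compound 1 to compound 3 (0.40 log units; beyond the scatter) is modest. Compound 2, `O=C(O)c1cccc(Cc2c(-c3ccsc3)nn3cc(Cl)ccc23)n1`, gives 110 nM, and the step of an 11-fold higher number from compound 2 to compound 3 (1.04 log units; beyond the scatter) is large. The two measured steps that end at compound 3 thus both show that exchanging the group on this aromatic carbon moves the number, and that the saturated cyclohexyl gives the weakest inhibitor of the three.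

Compound 4, `O=C(O)c1cccc(Cc2c(N3CCCC3)nn3cc(Cl)ccc23)n1`, differs from compound 3 in one place: pyrrolidin-1-yl in place of cyclohexyl on an aromatic carbon. Both the leaving and the entering group are saturated rings, so neither the thiophen-3-yl of compound 2 nor the 3-chlorophenyl of compound 1 tells directly what a second saturated ring with one nitrogen will do. Since the two aromatic groups gave lower numbers than cyclohexyl, and compound 3 already sits at the top, the expectation is that compound 4 stays near compound 3, with no step beyond the scatter, so that a 1.2-fold lower number from compound 3 to compound 4 (0.08 log units; within the scatter) is expected to be small. Compound 4 is therefore estimated at 1000 nM, in a range from 300 nM to 4000 nM.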

Compound 4, half-maximal inhibitory concentration: 1800 nM
Compound 4: the middle estimate sits 1.8-fold (0.26 log units) below what was measured; low and high end bracket the measured number.
By their numbers in this assay, from the lowest: compound 2; then compound 1; then compounds 3 and 4 (each within the scatter of the next).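

In this assay, the step of a 1.5-fold higher number from compound 3 to compound 4 (0.18 log units; within the scatter) shows that this position does not separate the two saturated rings, even though pyrrolidin-1-yl differs from cyclohexyl in ring size, in carrying a hetero atom and in its hydrogen-bond acceptor count. The gap to the aromatic groups also holds for this second saturated ring, with a 16-fold higher number from compound 2 to compound 4 (1.21 log units; beyond the scatter) and a 3.8-fold higher number from compound 1 to compound 4 (0.57 log units; beyond the scatter), so among these four compounds both saturated rings give higher numbers than both aromatic groups, and none of the four goes against this. Nothing measured here bears on why the numbers fall this way.

The compounds shown leave open whether the saturated rings share these numbers more generally, since a piperidin-1-yl or morpholin-4-yl group would separate the ring size and the hetero atom that change together between compound 3 and compound 4. They also leave open how an open-chain group such as dimethylamino or an unsubstituted phenyl or furan-3-yl ring would compare at this aromatic carbon, and thus whether the low number of compound 2 is particular to thiophen-3-yl.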